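The source may report more compounds than this note shows. Statements on the series, on what has been measured and on what is new or still open speak of the compounds shown alone.

Measured compounds:
Compound 1, `Cc1c(O)ccc2c1[C@H](Cn1cc(-c3ccc(F)cc3)nn1)[C@@]13CC(=O)[C@@](C)(CC[C@@H]21)C3`: in a functional assay on A549 cells (Homo sapiens) for cytotoxicity, read by MTT assay, with a stated time of 4 days (a higher number here means a weaker inhibitor, a lower number a stronger inhibitor), compound 1 gives > 20000 nM, which is a limit of the assay and not a number.
Compound 2, `C=C1C[C@]23C[C@@]1(O)CC[C@@H]2c1cccc(C)c1[C@@H]3Cn1cc(-c2ccc(Br)cc2)nn1`: in this assay compound 2 gives > 20000 nM, again a limit of the assay rather than a number.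
Compound 3, `C=C1C(=O)[C@]23C[C@@]1(O)CC[C@H]2c1ccc(OS(=O)(=O)c2ccc(C)cc2)c(C)c1[C@@H]3Cn1cc(-c2ccc(F)cc2)nn1`: in this assay compound 3 gives 1950 nM.

For the measured compounds named here, compound 2 therefore stands at the limit of > 20000 nM in this assay, at which 2 of the 3 values shown sit; only compound 3 has a measured number, and no pair of these three compounds differs in a single place, so no measured step exists to lean on.

Compound 4, `C=C1C[C@]23C[C@@]1(O)CC[C@@H]2c1cccc(C)c1[C@@H]3Cn1cc(-c2ccc(C)cc2)nn1`, is not yet measured. It differs from compound 2 by methyl in place of bromo on an aromatic carbon. Going by the values given here, nothing among the measured compounds shows what such a swap does in this assay. The expectation is a step from compound 2 to compound 4 of a step that the limit leaves unreadable from compound 2 to compound 4, which is none beyond the usual scatter. Compound 4 is estimated at 25000 nM, within 8000 nM to 80000 nM, most likely reported again as a limit.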

Compound 4, half-maximal inhibitory concentration: > 20000 nM
Compound 4 was reported as a limit; the forecaster's own chance of this, stated with the estimate: 75%; the middle value does not contradict the limit.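

Compound 2 and compound 4 give no readable step, because both are reported only as a limit and not as a number: the limit of > 20000 nM in this assay, at which 3 of the 4 values shown sit.

The compounds shown leave open what methyl in place of bromo on an aromatic carbon does in this assay.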